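From methyl to ethyl: compound 2 and compound 3

The source may report more compounds than this note shows. Statements on the series, on what has been measured and on what is new or still open speak of the compounds shown alone.

Measured in an ADME assay on Huh-7 cells (Homo sapiens) for cytotoxicity; on this read-out higher numbers stand for lower toxicity in this test and lower numbers for higher toxicity in this test:
- Compound 1 `O=c1[nH]c(=O)n([C@H]2C[C@@H](O)[C@@H](CO)O2)cc1Cl`: > 763000 nM
- Compound 2 `Cc1cn([C@@H]2O[C@H](CO)C=C2F)c(=O)[nH]c1=O`: > 413000 nM

Compound 2 stands at > 413000 nM, which is a limit of the assay and not a number. Compound 1 also gives only a limit, > 763000 nM. Neither compound therefore has an exact value, and the two cannot be ranked.

Compound 3 `CCc1cn([C@@H]2O[C@H](CO)C=C2F)c(=O)[nH]c1=O` departs from compound 2 by one change: methyl in place of hydrogen on a saturated chain carbon bound to an aromatic carbon. This places methyl in place of hydrogen on a saturated chain carbon bound to an aromatic carbon, turning methyl to ethyl.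

Going by the values given here, no measured pair shows the size of such a step, so no change beyond the usual scatter is expected in this assay, in either direction. The expected step is a step that the limit leaves unreadable from compound 2 to compound 3. For compound 3 the estimate is 450000 nM, with an expected range of 200000 nM to 900000 nM.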

Compound 3, half-maximal cytotoxic concentration: > 781000 nM
Compound 3: only a limit was reported; the forecaster's own chance of this, stated with the estimate: 80%; at least 1.7-fold (0.23 log units) between middle value and limit.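

In this assay compound 3 gives > 781000 nM, a limit of the assay and not a number. Compound 2 also gives only a limit, so no step can be read between compound 2 and compound 3. The compounds shown leave open whether methyl to ethyl changes the read-out at all.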